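A few compounds are considered here, and "the series" means these few. Any claim that something is new, unique, unknown or untested is made for them only; others in the source may bear on it.

Values so far in an ADME assay on Caco-2 cells (Homo sapiens) for permeability, read by LC-MS, in the apical to basolateral direction, with a stated time of 60 min, at pH 6.5 (on this read-out lower numbers stand for lower permeability and higher numbers for higher permeability), for the measured compounds:
- compound 1 `O=C(NCc1cc(Cl)ccc1-n1cnnn1)[C@@H]1C[C@@H]2C[C@@H]2N1C(=O)[C@H](O)CC1CC1` gives 3.6 10^-6 cm/s
- compound 2 `CC(C)(C)[C@@H](O)C(=O)N1[C@H](C(=O)NCc2cc(Cl)ccc2-n2cnnn2)C[C@@H]2C[C@@H]21` gives 16 10^-6 cm/s
- compound 3 `O=C(NCc1cc(Cl)ccc1-n1cnnn1)[C@@H]1C[C@@H]2C[C@@H]2N1C(=O)[C@H](O)c1ccccc1F` gives 16 10^-6 cm/s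

Compound 3 stands level with compound 2, and together they hold the highest of the three numbers. The change to compound 4 `O=C(NCc1cc(Cl)ccc1-n1cnnn1)[C@@H]1C[C@@H]2C[C@@H]2N1C(=O)[C@H](O)Cc1ccccn1` reads (pyridin-2-yl)methyl in place of 2-fluorophenyl on a saturated chain carbon bound to a carbonyl carbon and an oxygen on a saturated carbon and amounts to (pyridin-2-yl)methyl in place of 2-fluorophenyl on a saturated chain carbon bound to a carbonyl carbon and an oxygen on a saturated carbon. The step of no change at the digits printed from compound 2 to compound 3 (within the scatter) stays within the scatter and gives little guidance. The steps of a 4.4-fold higher number from compound 1 to compound 2 (0.65 log units; beyond the scatter) and a 4.4-fold higher number from compound 1 to compound 3 (0.65 log units; beyond the scatter) are modest but beyond the scatter. Among the measured compounds shown here, compound 1 is the one measured compound whose group, like (pyridin-2-yl)methyl, is a ring carried on a methyl, so it is the closest guide, though a loose one. A fall from compound 3 somewhat smaller than a 4.4-fold higher number from compound 1 to compound 3 (0.65 log units; beyond the scatter) is therefore expected in this assay and would lie just beyond the scatter. The expected step is a 2.7-fold lower number from compound 3 to compound 4 (0.43 log units; beyond the scatter) on this reading. Compound 4 is estimated at 6 10^-6 cm/s with an expected range from 2.5 10^-6 cm/s to 14 10^-6 cm/s for now.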

Compound 4, apparent permeability: 1.2 10^-6 cm/s
Compound 4: the middle estimate sits 5.0-fold (0.70 log units) above what was measured, and the stated range ends above it.
By their numbers in this assay, from the lowest: compound 4; then compound 1; then compounds 2 and 3 (each within the scatter of the next).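

Moving to (pyridin-2-yl)methyl gives the first large steps seen at this position in this assay (a 13-fold lower number from compound 3 to compound 4 (1.12 log units; beyond the scatter); a 13-fold lower number from compound 2 to compound 4 (1.12 log units; beyond the scatter)), whereas the earlier steps here were modest at most. The number also falls against the other ring carried on a methyl (a 3.0-fold lower number from compound 1 to compound 4 (0.48 log units; beyond the scatter)), so among these four compounds the two groups with a ring on a methyl hold the two lowest numbers, and the one with a ring nitrogen lies lower. No measurement at hand gives a reason for these falls.

From the compounds shown here alone, compound 4 differs from compound 3 in both the ring nitrogen and the methyl link, so their separate shares of the fall remain open. A benzyl group, with a ring of carbon only on the same methyl, and a pyridin-2-yl group set directly on the saturated chain carbon would pull the two apart.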